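Swapping a Furan for a Hydroxyl Chain on a Sulfamate

This account rests on a few compounds, and the source may have more. Where it says the series, first, only, none or still open, it means among the compounds named here.

Compound 1: `CN(C)CCN(CCN(C)C)c1ccc(C(=O)N2CCc3ccc(OS(N)(=O)=O)cc3C2)cc1`, 15.9%
Compound 2: `NS(=O)(=O)Oc1ccc2c(c1)CN(C(=O)c1cccc(N(Cc3ccccc3)Cc3ccco3)c1)CC2`, 90.5%

In an assay on HEK293 cells for inhibition of Steryl-sulfatase (Homo sapiens), tested at 1 uM (a lower number here means a weaker effect, a higher number a stronger effect of the compound at the concentration tested), compound 2 gives 90.5%, the higher of the two numbers recorded, while compound 1 gives 15.9% in this assay, a difference that lies beyond the usual scatter. Compound 3 is `NS(=O)(=O)Oc1ccc2c(c1)CN(C(=O)c1cccc(N(CCCO)Cc3ccccc3)c1)CC2` and has not yet been measured. It is derived from compound 2 by the change (2-hydroxyethyl in place of furan-2-yl on a saturated chain carbon bound to a nitrogen on an aromatic ring). Among the measured compounds shown here, the change sits on a saturated chain carbon bound to a nitrogen on an aromatic ring, far from the shared core, and there is no comparable pair among the measured compounds to guide the reader. Compound 3 is expected to keep most of the inhibition seen for compound 2, with a step of a number 10.5 percentage points lower from compound 2 to compound 3 (beyond the scatter) that is small and downward, if any beyond the scatter. Compound 3 is estimated at 80%, with a range from 55% to 97%.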

Compound 3, a percentage reported as inhibition, at one concentration (the size of the read-out at that concentration, not a potency): 37.3%
Compound 3: middle estimate off by 42.7 percentage points, on the high side, and the stated range ends above it.
By their numbers in this assay, from the lowest: compound 1; then compound 3; then compound 2.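

The change to 2-hydroxyethyl in place of furan-2-yl gives a number 53.2 percentage points lower from compound 2 to compound 3 (beyond the scatter) in this assay, so this place, on a saturated chain carbon bound to a nitrogen on an aromatic ring, clearly registers what is attached there. Among the compounds shown here, the exchange removes a five-membered aromatic ring with 1 hetero atom and brings in a hydrogen-bond donor, and these two differences arrive together in the single pair, so they cannot be told apart. No measurement at hand accounts for the drop.

As far as these compounds go, it remains open whether the loss follows the missing ring or the added hydroxyl end of the chain. A plain propyl chain, a phenyl ring or a thiophene at this place would each separate those two readings, and an amine at the chain end would test the hydroxyl further.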